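Oxazolyl amide on the hexafluoro-carbinol naphthylamine core

The source may hold more compounds than are shown below. What is called first, only, known or untested is meant among the compounds shown, and "the series" means these compounds.

Measured compounds:
compound 1 `O=C(CCc1ccccc1)Nc1c(C(O)(C(F)(F)F)C(F)(F)F)ccc2ccccc12`: 1750 nM
compound 2 `N#Cc1cccc(C(=O)Nc2c(C(O)(C(F)(F)F)C(F)(F)F)ccc3ccccc23)c1`: 12 nM

In an assay on LtK cells with ATP-sensitive inward rectifier potassium channel 11 (Homo sapiens) as the target (on this read-out higher numbers stand for an effect only at larger amounts of compound and lower numbers for an effect already at smaller amounts), compound 2 gives 12 nM and stands as the lower of the two numbers shown; compound 1 gives 1750 nM. Going by the values given here, the one measured step, a 150-fold lower number from compound 1 to compound 2 (2.16 log units; beyond the scatter), shows what the change of the group on the carbonyl carbon can do on this core.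

Compound 3 `O=C(Nc1c(C(O)(C(F)(F)F)C(F)(F)F)ccc2ccccc12)c1cnco1` has not been measured. It differs from compound 2 as follows: 1,3-oxazol-5-yl in place of 3-cyanophenyl on a carbonyl carbon. Among the compounds with values here, no measured pair swaps one aromatic group for another; the only step available compares an aromatic group with a phenethyl chain, so it bears on this change only loosely. Because a 150-fold lower number from compound 1 to compound 2 (2.16 log units; beyond the scatter) is large, the aromatic group at this position is expected to matter, and a smaller aromatic ring without the nitrile is expected to give a modest rise in the number, a 4.2-fold higher number from compound 2 to compound 3 (0.62 log units; beyond the scatter). Compound 3 is thus estimated at 50 nM, in the range 10 nM to 300 nM.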

Compound 3, half-maximal effective concentration: 24 nM
For compound 3 the middle estimate is 2.1-fold (0.32 log units) above the measured one, and the stated range covers the measured number.
By their numbers in this assay, from the lowest: compounds 2 and 3 (each within the scatter of the next); then compound 1.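

In this assay, the swap on the carbonyl carbon gives a 2.0-fold higher number from compound 2 to compound 3 (0.30 log units; within the scatter), so at this position the 3-cyanophenyl group, with its six-membered carbon ring and nitrile, cannot be told apart from the 1,3-oxazol-5-yl group, a five-membered aromatic ring with 2 hetero atoms. Going by these compounds alone, the earlier step set only one aromatic group against phenethyl; a second aromatic group now repeats that contrast, with a 73-fold lower number from compound 1 to compound 3 (1.86 log units; beyond the scatter), so neither the nitrile nor a six-membered ring is needed for the large gap from phenethyl. Nothing available gives a reason for either step.

The compounds shown leave open how a plain phenyl or a benzyl group would read on this carbonyl carbon. They also leave open what a carboxylic acid or an amine carried on the 1,3-oxazol-5-yl ring would do.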